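The source may report more compounds than this note shows. Statements on the series, on what has been measured and on what is new or still open speak of the compounds shown alone.

Three compounds share one core and differ mainly in the chain that hangs from a saturated ring carbon. Compound 1 `CC(=O)NCC[C@@H]1C[C@@H](c2ccc(F)c(F)c2)[C@H](NC(=O)c2cc(-c3c(Cl)cnn3C)c(Cl)o2)CN1` carries an acetamidomethyl group there and gives 2.49 nM in an assay for inhibition of RAC-alpha serine/threonine-protein kinase (Homo sapiens), read by HTRF, with a stated time of 1 h; on this read-out higher numbers stand for weaker inhibition and lower numbers for stronger inhibition. Compound 3 `Cn1ncc(Cl)c1-c1cc(C(=O)N[C@@H]2CN[C@H](CC(O)CO)C[C@H]2c2ccc(F)c(F)c2)oc1Cl`, which carries 1,2-dihydroxyethyl instead, gives 3.31 nM in this assay; the step of a 1.3-fold higher number from compound 1 to compound 3 (0.12 log units; within the scatter) shows that this change made no difference worth noting. Compound 2 `Cn1ncc(Cl)c1-c1cc(C(=O)N[C@@H]2CN[C@H](CCN3CCCC3)C[C@H]2c2ccc(Cl)c(Cl)c2)oc1Cl`, with 2-(pyrrolidin-1-yl)ethyl on the chain and two chlorine atoms on the attached aromatic ring, gives 6.41 nM and so stands highest of the three, within the scatter of compound 3 but beyond it relative to compound 1.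

The next compound, compound 4 `CN(C)CC[C@@H]1C[C@@H](c2ccc(Cl)c(Cl)c2)[C@H](NC(=O)c2cc(-c3c(Cl)cnn3C)c(Cl)o2)CN1`, keeps everything of compound 2 except one change: dimethylamino in place of pyrrolidin-1-yl on a saturated chain carbon, two bonds along the chain from a saturated ring carbon. For the measured compounds named here, the only measured step at a comparable place is the one from compound 1 to compound 3, and it stayed within the scatter. Going by the values given here, no measured pair swaps one amine for another, so the evidence is thin, but nothing so far suggests that altering this chain end moves the number much. A step of a 1.2-fold lower number from compound 2 to compound 4 (0.07 log units; within the scatter) is therefore expected, meaning no change beyond the scatter. Compound 4 is estimated at 5.5 nM, with a likely range from 2.2 nM to 14 nM.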

Compound 4, half-maximal inhibitory concentration: 3.4 nM
Beside the measured number, compound 4's estimate is 1.6-fold (0.21 log units) above it; the measured number falls inside the stated range.
By their numbers in this assay, from the lowest: compounds 1, 3, 4 and 2 (each within the scatter of the next, the first and the last beyond it).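

For the compounds shown here, this is the first measured pair in which one amine replaces another on a saturated chain carbon, two bonds along the chain from a saturated ring carbon, and in this assay the step is a 1.9-fold lower number from compound 2 to compound 4 (0.28 log units; within the scatter) and so stays within the scatter. Dimethylamino has no ring and fewer heavy atoms than pyrrolidin-1-yl, yet the counts of hydrogen-bond donors and acceptors are the same, so for this one pair the ring at the chain end is not needed to keep the number within the scatter. Nothing measured here explains why the number holds when the ring is lost.

From the compounds shown here alone, both amine compounds carry two chlorine atoms on the attached aromatic ring, so it remains open whether the same swap would behave alike with two fluorine atoms, as in compound 1 and compound 3. Going by these compounds, it also remains open what a primary amine, a morpholin-4-yl group or a carboxylic acid at this chain end would do, or a longer chain carrying the dimethylamino group.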